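The source may hold more compounds than are shown below. What is called first, only, known or untested is meant among the compounds shown, and "the series" means these compounds.

Measured so far in a toxicity assay on THP-1 cells (Homo sapiens) for inhibition; on this read-out lower numbers stand for higher toxicity in this test and higher numbers for lower toxicity in this test:
- compound 1 `COc1ccc(-c2cn(C)c(NC(=O)c3ccc(F)cc3)n2)cc1`: > 50000 nM (a limit)
- compound 2 `Cc1ccccc1-c1cnc(NC(=O)c2ccc(F)cc2)n1C`: > 50000 nM (a limit)
- compound 3 `Cn1c(-c2ccccc2[N+](=O)[O-])cnc1NC(=O)c1ccc(F)cc1`: 31000 nM

Compound 2 gives > 50000 nM, which is a limit of the assay and not an exact number. It stands at the limit of > 50000 nM in this assay, at which 2 of the 3 values shown sit.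

Compound 4 `Cn1c(-c2cccc(C#N)c2)cnc1NC(=O)c1ccc(F)cc1` differs from compound 2 as follows: 3-cyanophenyl in place of 2-methylphenyl on an aromatic carbon. For the measured compounds named here, the one measured step that bears on this change is an at least 1.6-fold lower number from compound 2 to compound 3 (0.20 log units; that floor lies within the scatter). That step also removes the methyl group, and the measured floor of its size stays within the scatter.

Going by the values given here, with only this step as a guide, no change beyond the scatter is expected. The expected size is a number no higher from compound 2 to compound 4 (the limit leaves the size open). For compound 4 the estimated value is 50000 nM, with an expected range from 25000 nM to 100000 nM.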

Compound 4, half-maximal cytotoxic concentration: > 100000 nM
Compound 4 gave a limit, no number; the forecaster's own chance of this, stated with the estimate: 75%; middle value at least 2.0-fold (0.30 log units) from the limit.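

Compound 2 and compound 4 both give limits of the assay, not numbers, and the step between them cannot be read. The compounds shown leave open whether 3-cyanophenyl in place of 2-methylphenyl changes the toxicity at all, and by how much.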